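This account rests on a few compounds, and the source may have more. Where it says the series, first, only, none or still open, it means among the compounds named here.

In a functional assay on MCF7 cells (Homo sapiens) (a lower number here means a stronger inhibitor of growth, a higher number a weaker inhibitor of growth), compound 2 `O=S(=O)(/C=C/c1ccc(F)cc1F)Cc1ccc(Nc2ncnc3ccccc23)cc1` gives > 100000 nM, which is a limit of the assay and not a number. Two close relatives do give numbers: compound 1 `O=S(=O)(/C=C/c1ccc(Cl)c(Cl)c1)Cc1ccc(Nc2ncnc3ccccc23)cc1` gives 28000 nM, and compound 3 `O=S(=O)(/C=C/c1ccc(C(F)(F)F)cc1F)Cc1ccc(Nc2ncnc3ccccc23)cc1` gives 100000 nM.

Compound 4 `O=S(=O)(/C=C/c1ccc(F)cc1F)Cc1ccc(Nc2ncnc3cc(Cl)ccc23)cc1` differs from compound 2 only on the shared core: chloro in place of hydrogen on an aromatic carbon. This is chloro in place of hydrogen on an aromatic carbon. Within the data shown here, no measured step changes that part of the molecule, so the evidence is indirect. The measured steps instead alter the substituted phenyl group on the chain. They are an at least 3.5-fold higher number from compound 1 to compound 2 (0.55 log units; beyond the scatter) and a 3.6-fold higher number from compound 1 to compound 3 (0.55 log units; beyond the scatter), both modest, while a number no higher from compound 2 to compound 3 (the limit leaves the size open) leaves its size open. Going by an at least 3.5-fold higher number from compound 1 to compound 2 (0.55 log units; beyond the scatter), the chlorine-bearing compound 1 sits on the lower side, but its chloro groups lie elsewhere, so this is only a weak guide.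

A modest step towards a lower number is therefore expected in this assay, and a result still at the limit would be no surprise. The expected change is an at least 1.6-fold lower number from compound 2 to compound 4 (0.22 log units; that floor lies within the scatter). The estimate for compound 4 is 60000 nM, with an expected range from 20000 nM to 100000 nM.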

Compound 4, concentration for 50% growth inhibition: > 100000 nM
Compound 4: only a limit was reported; the forecaster's own chance of this, stated with the estimate: 40%; at least 1.6-fold (0.22 log units) between middle value and limit.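

In this assay, compound 2 and compound 4 both sit at the same limit rather than at a number, so no step between them can be read: the limit of > 100000 nM in this assay, at which 2 of the 4 values shown sit.

The compounds shown leave open whether chloro in place of hydrogen on this aromatic carbon changes growth inhibition at all.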